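Changing the Amine Ring at the Far End of Compound 2

This account rests on a few compounds, and the source may have more. Where it says the series, first, only, none or still open, it means among the compounds named here.

Measured compounds:
Compound 1 `COc1ccc(F)c(-c2ccc3c(NC(=O)c4ccc(N5CCCN(C)CC5)cc4)n[nH]c3c2)c1F` gives 51.5 nM in a functional assay on KG-1 cells (Homo sapiens) for antiproliferative activity, read by CCK-8 assay, with a stated time of 72 h; a higher number here means a weaker inhibitor, a lower number a stronger inhibitor.
Compound 2 `CCN1CCN(c2ccc(C(=O)Nc3n[nH]c4cc(-c5c(F)ccc(OC)c5F)ccc34)cc2)CC1` gives 25.3 nM in this assay.

Compound 2 holds the lowest of the two measured numbers, and its nearest neighbour is compound 1, which sits a 2.0-fold lower number from compound 1 to compound 2 (0.31 log units; beyond the scatter) away in the direction of stronger inhibition; that step came from exchanging one amine ring for another on an aromatic carbon. Compound 3 `COc1ccc(F)c(-c2ccc3c(NC(=O)c4ccc(N5C[C@@H](C)N[C@@H](C)C5)cc4)n[nH]c3c2)c1F` has not yet been measured. It differs from compound 2 in one place: 3,5-dimethylpiperazin-1-yl in place of 4-ethylpiperazin-1-yl on an aromatic carbon. Going by the values given here, the only step that bears on this change is the one from compound 1 to compound 2, a ring swap at the same place, which was modest in size. Because that step was only a 2.0-fold lower number from compound 1 to compound 2 (0.31 log units; beyond the scatter), a comparably small effect is expected here, with a slight lean towards a weaker inhibitor since the new ring adds a hydrogen-bond donor. Compound 3 is therefore estimated at 40 nM, between 15 nM and 110 nM, a step of a 1.6-fold higher number from compound 2 to compound 3 (0.20 log units; within the scatter).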

Compound 3, half-maximal inhibitory concentration: 348 nM
The estimate for compound 3 lay 8.7-fold (0.94 log units) below the measured number; measured number outside the range, above it.
By their numbers in this assay, from the lowest: compound 2; then compound 1; then compound 3.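

This position is far less forgiving than the first ring swap suggested. Exchanging 4-ethylpiperazin-1-yl for 3,5-dimethylpiperazin-1-yl keeps the ring size and heavy-atom count, yet gives a 14-fold higher number from compound 2 to compound 3 (1.14 log units; beyond the scatter) in this assay, and the same group also compares poorly with 4-methyl-1,4-diazepan-1-yl, with a 6.8-fold higher number from compound 1 to compound 3 (0.83 log units; beyond the scatter), which leaves compound 3 the weakest of the three. The entering ring differs from the leaving one by a hydrogen-bond donor and two defined stereocentres, and nothing measured here accounts for the drop.

As far as these compounds go, it remains open whether the loss follows the added donor, the two methyl groups or their spatial arrangement. A plain piperazin-1-yl ring, a morpholine ring or the other stereoisomer of the dimethyl ring would help to separate these features.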